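A few compounds are considered here, and "the series" means these few. Any claim that something is new, unique, unknown or untested is made for them only; others in the source may bear on it.

Measured compounds in a functional assay on trachea (Cavia porcellus); a lower number here means a stronger inhibitor, a higher number a weaker inhibitor:
compound 1, `CO[C@@]12CCN(C)C[C@H]1[C@H](c1ccc(Cl)cc1Cl)C(C#N)=C(N)O2`: 14900 nM
compound 2, `CCN1CC[C@@]2(OC)OC(N)=C(C#N)[C@@H](c3ccc(Cl)cc3Cl)[C@@H]2C1`: 27100 nM
compound 3, `CCCN1CC[C@@]2(OC)OC(N)=C(C#N)[C@@H](c3ccc(Cl)cc3Cl)[C@@H]2C1`: 35500 nM

Compound 3 gives the highest of the three numbers in this assay: a 2.4-fold higher number from compound 1 to compound 3 (0.38 log units; beyond the scatter), whereas a 1.3-fold higher number from compound 2 to compound 3 (0.12 log units; within the scatter) and a 1.8-fold higher number from compound 1 to compound 2 (0.26 log units; within the scatter). All three measured steps concern only the substituent on the saturated chain carbon bound to the amine nitrogen in the ring; the aryl group stays the same across compounds 1, 2 and 3.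

Compound 4, `CCCN1CC[C@@]2(OC)OC(N)=C(C#N)[C@@H](c3ccc(C)cc3)[C@@H]2C1`, is not yet measured. It differs from compound 3 in 4-methylphenyl in place of 2,4-dichlorophenyl on a saturated ring carbon. Among the compounds with values here, none of the measured steps bears on this exchange: each of them alters the chain on the ring nitrogen, and no pair of measured compounds differs in the aryl group. Within the data shown here, the data therefore give no direction and no size for this step, and the expectation is placed at the number of compound 3 with a wide range to either side. Compound 4 is expected to give 40000 nM in this assay, with a range from 8000 nM to 200000 nM. The estimated step of a 1.1-fold higher number from compound 3 to compound 4 (0.05 log units; within the scatter) carries no direction beyond the scatter, as nothing measured supports one.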

Compound 4, half-maximal inhibitory concentration: 21000 nM
The estimate for compound 4 lay 1.9-fold (0.28 log units) above the measured number, within the range that was stated.
By their numbers in this assay, from the lowest: compounds 1, 4, 2 and 3 (each within the scatter of the next, the first and the last beyond it).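

In this assay, the position on the saturated ring carbon now has its first reading: 4-methylphenyl in place of 2,4-dichlorophenyl gives a 1.7-fold lower number from compound 3 to compound 4 (0.23 log units; within the scatter). With the chain on the ring nitrogen held constant, this exchange removes both chlorine atoms and adds a methyl group without a step beyond the scatter, so compound 3 and compound 4 cannot be told apart in this assay, and this single pair shows no requirement for the 2,4-dichlorophenyl group at this position. The data offer no measurement that would account for this result.

As far as these compounds go, whether an unsubstituted phenyl, a 4-methoxyphenyl or a pyridine ring at this position would separate from compound 3 beyond the scatter remains open, and a single exchange gives no trend across aryl groups. From the compounds shown here alone, it is also open whether 4-methylphenyl would give a similar step with the methyl or ethyl chain on the ring nitrogen of compound 1 and compound 2, or with a longer chain there.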